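Chloro in Place of Fluoro: From Compound 2 to Compound 4

This account rests on a few compounds, and the source may have more. Where it says the series, first, only, none or still open, it means among the compounds named here.

Compound 1, `CCC(C(=O)N1CCN(c2ccccc2Cl)CC1)N1C(=O)CCC1=O`: 50%
Compound 2, `CC(C(=O)N1CCN(c2ccccc2F)CC1)N1C(=O)CCC1=O`: 100%
Compound 3, `CCC(C(=O)N1CCN(c2ccccc2F)CC1)N1C(=O)CCC1=O`: 100%

All three compounds were tested in a functional assay on the whole organism (strain Swiss) with Mus musculus as the target, in the maximal electroshock model, with a stated time of 0.25 h, at a dose of 300 mg/kg by the intraperitoneal route; a lower number here means a weaker effect, a higher number a stronger effect of the compound at the dose given. Compound 2 stands level with compound 3 at the digits printed, and together they give the highest of the three numbers; compound 1 lies well below them. The two measured steps frame what the unmeasured compound might do. Between compound 1 and compound 3, a number 50 percentage points higher from compound 1 to compound 3 (beyond the scatter), a fluoro replacing a chloro lifted the read-out strongly. Between compound 2 and compound 3, no change at the digits printed from compound 2 to compound 3 (within the scatter), a methyl added on the saturated chain carbon made no difference within the scatter.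

Compound 4, `CC(C(=O)N1CCN(c2ccccc2Cl)CC1)N1C(=O)CCC1=O`, is compound 2 with one change: chloro in place of fluoro on an aromatic carbon. This is the exact reverse of the exchange that separates compound 1 from compound 3, so the large upward step seen there is expected to run backward here. Compound 4 also relates to compound 1 by the same methyl-for-hydrogen swap that left compound 2 and compound 3 level, which points to compound 4 sitting near compound 1. A clear drop is therefore expected, a number 50 percentage points lower from compound 2 to compound 4 (beyond the scatter). Compound 4 is estimated at 50%, in a range from 20% to 80%.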

Compound 4, a percentage reported as activity, at one dose (the size of the read-out at that dose, not a potency): 0%
Beside the measured number, compound 4's estimate is 50 percentage points above it, and the stated range ends above it.
By their numbers in this assay, from the lowest: compound 4; then compound 1; then compounds 2 and 3 (each within the scatter of the next).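

In this assay, going from 2-fluorophenyl to 2-chlorophenyl on the core of compound 2 gives a number 100 percentage points lower from compound 2 to compound 4 (beyond the scatter), so this exchange is not worth a fixed amount and its size depends on the rest of the molecule: the same change on two cores in this assay, a number 50 percentage points higher (beyond the scatter) from compound 1 to compound 3 and a number 100 percentage points higher (beyond the scatter) from compound 4 to compound 2, 50 percentage points apart, beyond the scatter of two such steps. The methyl on the saturated chain carbon also turns out not to be silent, since its exchange for hydrogen gives a number 50 percentage points lower from compound 1 to compound 4 (beyond the scatter), although the same exchange changed nothing between the two fluoro compounds: the same change on two cores in this assay, no change at the digits printed (within the scatter) from compound 2 to compound 3 and a number 50 percentage points higher (beyond the scatter) from compound 4 to compound 1, 50 percentage points apart, beyond the scatter of two such steps. Taken together, the four compounds show that the halogen on the aromatic carbon and the chain next to the carbonyl do not act independently, as the chain makes a difference with chloro on the ring and none with fluoro.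

The compounds shown leave open whether a methoxy or a trifluoromethyl group at the same aromatic carbon would behave like fluoro or like chloro, and how a longer chain would fare with each halogen. With a read-out taken at one dose, compound 2 and compound 3 also remain unseparated in the size of their effect at that dose, as both give 100%.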